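The source may hold more compounds than are shown below. What is called first, only, known or untested is meant among the compounds shown, and "the series" means these compounds.

Compound 1 `Cc1nn2c(-c3nc4cc(C)c(C)cc4[nH]3)c(-c3ccccc3)nc2s1`: > 30000 nM
Compound 2 `Cc1ccc2[nH]c(-c3c(-c4ccc(F)cc4)nc4sc(C)nn34)nc2c1`: 11700 nM

Among the compounds with values here, in a functional assay on A549 cells (Homo sapiens) for antiproliferative activity, read by MTT assay (on this read-out lower numbers stand for stronger inhibition and higher numbers for weaker inhibition), compound 2 gives 11700 nM, the only true number so far. Compound 1 reads > 30000 nM, which is a limit of the assay and not a number. Compound 3 `Cc1nn2c(-c3nc4cc(C)c(C)cc4[nH]3)c(-c3ccc(F)cc3)nc2s1` differs from compound 2 in one place: methyl in place of hydrogen on an aromatic carbon. Within the data shown here, no measured pair shows this change, so only a small step is expected in this assay, perhaps none beyond the scatter. The slight expected lean towards weaker inhibition rests on compound 1, with its limit of > 30000 nM. The estimated change is a 1.4-fold higher number from compound 2 to compound 3 (0.14 log units; within the scatter). For compound 3, the expected value is 16000 nM, within an estimated range of 7000 nM to 30000 nM.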

Compound 3, half-maximal inhibitory concentration: > 30000 nM
Compound 3: a limit, no number; the forecaster's own chance of this, stated with the estimate: 30%; at least 1.8-fold (0.27 log units) between middle value and limit.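

Methyl in place of hydrogen on an aromatic carbon, ortho to a methyl group, gives an at least 2.5-fold higher number from compound 2 to compound 3 (0.40 log units; beyond the scatter), the first measured step for this change at this position. Compound 3 reads > 30000 nM, which is a limit and not a number. The full size of the step stays unknown because the reading ends at a limit: the limit of > 30000 nM in this assay, at which 2 of the 3 values shown sit.

The step between compound 1 and compound 3 cannot be read. The compounds shown leave open how a larger group at this position, such as an amine or a longer chain, would behave.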